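Methylating the aminopyrimidine nitrogen of compound 2

This account rests on a few compounds, and the source may have more. Where it says the series, first, only, none or still open, it means among the compounds named here.

Measured so far:
compound 1 `CC(C)(C)c1ccc(S(=O)(=O)Nc2ccc(Cl)cc2-c2ncccc2CO)cc1` gives 89 nM
compound 2 `CC(C)(C)c1ccc(S(=O)(=O)Nc2ccc(Cl)cc2-c2nc(N)ncc2O)cc1` gives 4 nM

In a functional assay on isolated protein for antagonist activity at C-C chemokine receptor type 9 (Homo sapiens), read by calcium flux, with a stated time of 10 min (on this read-out lower numbers stand for stronger inhibition and higher numbers for weaker inhibition), compound 2 stands lowest of the two numbers; its nearest neighbour is compound 1, and the change of ring in a 22-fold lower number from compound 1 to compound 2 (1.35 log units; beyond the scatter) was large and beyond the scatter. Compound 3 `CNc1ncc(O)c(-c2cc(Cl)ccc2NS(=O)(=O)c2ccc(C(C)(C)C)cc2)n1` differs from compound 2 only by methyl in place of hydrogen on a nitrogen on an aromatic ring. Within the data shown here, no measured step bears on this change: the one step known swaps a whole aromatic ring, and nothing shows what a methyl on the ring nitrogen does. With nothing to weigh, the step from compound 2 to compound 3 is expected to fall within the scatter, and the estimate for compound 3 is 6 nM with a range of 2 nM to 20 nM, which corresponds to an expected 1.5-fold higher number from compound 2 to compound 3 (0.18 log units; within the scatter).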

Compound 3, half-maximal inhibitory concentration: 27 nM
Beside the measured number, compound 3's estimate is 4.5-fold (0.65 log units) below it; measured number above the stated range.
By their numbers in this assay, from the lowest: compound 2; then compound 3; then compound 1.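

In this assay, the nitrogen of the amino group of compound 2 proves sensitive to even the smallest addition, since going from amino to methylamino gives a 6.8-fold higher number from compound 2 to compound 3 (0.83 log units; beyond the scatter) and so gives back much of the gain that the change of ring had brought. That gain is not lost entirely. Compound 3 still keeps a modest edge over the ring of compound 1, with a 3.3-fold lower number from compound 1 to compound 3 (0.52 log units; beyond the scatter) beyond the scatter. Nothing available explains why a single methyl on this nitrogen has this effect.

The compounds shown leave open whether the number keeps rising with a longer chain on this nitrogen, such as ethyl or propyl, or with a second methyl, as in dimethylamino. With only one substituent here, a single step cannot establish a trend at this position.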